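A few compounds are considered here, and "the series" means these few. Any claim that something is new, unique, unknown or untested is made for them only; others in the source may bear on it.

Working notes on the series. In a functional assay with platelet-activating factor receptor (Cavia porcellus) as the target (a lower number here means that less compound is needed, a higher number that more compound is needed for the effect), compound 3 `COc1ccc(/C(=C/C=C/C(=O)N[C@H](C)CCCc2cccnc2)C2CCCCC2)cc1` gives 0.21 mg/kg, the highest of the three numbers, though its gap to compound 2 lies within scatter. Compound 1 `CCCCCCCC/C(=C\C=C\C(=O)N[C@H](C)CCCc1cccnc1)c1ccc(OC)cc1` gives 0.1 mg/kg and compound 2 `COc1ccc(/C(=C/C=C/C(=O)N[C@H](C)CCCc2cccnc2)c2ccccc2)cc1` gives 0.16 mg/kg. The measured steps at this position were a 2.1-fold higher number from compound 1 to compound 3 (0.32 log units; beyond the scatter), a 1.3-fold higher number from compound 2 to compound 3 (0.12 log units; within the scatter) and a 1.6-fold higher number from compound 1 to compound 2 (0.20 log units; within the scatter). Compound 4 `CCC/C(=C\C=C\C(=O)N[C@H](C)CCCc1cccnc1)c1ccc(OC)cc1` carries propyl in place of cyclohexyl on a double-bonded chain carbon bound to an aromatic carbon and a double-bonded chain carbon. Among the compounds with values here, no measured step shortens a chain here, so the bearing of the known steps is indirect: the chain substituent in compound 1 sat at the low end, the ring-for-ring swap stayed within scatter. For compound 4 a step of a 1.2-fold lower number from compound 3 to compound 4 (0.07 log units; within the scatter) is expected, small and uncertain in direction. Compound 4 is estimated at 0.18 mg/kg, within 0.07 mg/kg to 0.5 mg/kg.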

Compound 4, dose for 50% inhibition: 0.52 mg/kg
Compound 4: middle estimate off by 2.9-fold (0.46 log units), on the low side; measured number outside the range, above it.
By their numbers in this assay, from the lowest: compounds 1, 2 and 3 (each within the scatter of the next, the first and the last beyond it); then compound 4.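

At this position, this assay now separates the propyl compound from the rest: propyl in place of cyclohexyl gives (a 2.5-fold higher number from compound 3 to compound 4 (0.39 log units; beyond the scatter)) and propyl in place of phenyl gives (a 3.3-fold higher number from compound 2 to compound 4 (0.51 log units; beyond the scatter)), while octyl, phenyl and cyclohexyl spanned only (a 2.1-fold higher number from compound 1 to compound 3 (0.32 log units; beyond the scatter)). An open chain alone therefore does not hold the low number, since shortening octyl to propyl gives the largest step in the set (a 5.2-fold higher number from compound 1 to compound 4 (0.72 log units; beyond the scatter)). No available evidence bears on this rise.

From the compounds shown here alone, whether a pentyl chain or a chain longer than octyl would follow the same trend remains open. So does the effect of an amine or a carboxylic acid at the end of the chain.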